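A few compounds are considered here, and "the series" means these few. Any claim that something is new, unique, unknown or untested is made for them only; others in the source may bear on it.

Working notes on the step to compound 4 (`Cc1c2c(n3c1CC(=O)N(C)CC[C@H](C)Nc1cc-3ccc1C(N)=O)CC(C)(C)CC2=O`), read in an in vitro ADME assay on microsomes from liver (Rattus norvegicus) for metabolic stability (a lower number here means that the compound disappears faster, a higher number that the compound lasts longer), alone. Compound 3 (`Cc1c2c(n3c1CC(=O)N(CCN(C)C)CC[C@H](C)Nc1cc-3ccc1C(N)=O)CC(C)(C)CC2=O`) gives > 0.5 h and this is a limit of the assay, not a number. Compound 1 (`COCCN1CC[C@H](C)Nc2cc(ccc2C(N)=O)-n2c(c(C)c3c2CC(C)(C)CC3=O)CC1=O`) gives > 0.5 h and this too is a limit. Compound 2 (`Cc1c2c(n3c1CC(=O)NCC[C@H](C)Nc1cc-3ccc1C(N)=O)CC(C)(C)CC2=O`) gives > 0.5 h as a limit as well. Among the compounds with values here, the series so far therefore has a single reading (the limit of > 0.5 h in this assay, at which 3 of the 3 values shown sit).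

The change from compound 3 to compound 4 is hydrogen in place of (dimethylamino)methyl on a saturated chain carbon bound to an amide-type nitrogen in a ring and amounts to hydrogen in place of (dimethylamino)methyl on a saturated chain carbon bound to an amide-type nitrogen in a ring. Cut one bond further out, it reads 2-(dimethylamino)ethyl to methyl.

The closest measured step is a step that the two limits leave unreadable from compound 2 to compound 3 and the two others that bear on it are a step that the two limits leave unreadable from compound 1 to compound 2 and a step that the two limits leave unreadable from compound 1 to compound 3 in the same assay. None of the three has a readable size, so they support no direction in this assay and no expected change beyond the scatter. The step expected is a step that the limit leaves unreadable from compound 3 to compound 4 and a further report as a limit is the likeliest outcome. The estimated value for compound 4 is 0.8 h with an expected range from 0.4 h to 2 h on this reading.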

Compound 4, half-life: > 0.5 h
Compound 4 ended at the assay's limit; the forecaster's own chance of this, stated with the estimate: 85%; the middle value is on the limit's open side.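

No step among compound 1, compound 2, compound 3 and compound 4 can be read in this assay because every value is a limit: the limit of > 0.5 h in this assay, at which 4 of the 4 values shown sit.

The compounds shown leave open the actual half-life of each compound, and so whether the group on the amide-type nitrogen in the ring makes any difference in this assay.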